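Cyclobutyl for Ethyl on the Amide Nitrogen

The source may report more compounds than this note shows. Statements on the series, on what has been measured and on what is new or still open speak of the compounds shown alone.

Measured compounds:
Compound 1, `Cc1cccc2c1CC/C2=C\C(=O)NC1CC1`: 15%
Compound 2, `CCNC(=O)/C=C1\CCc2ccc(F)cc21`: 45%

Going by the values given here, in a functional assay on the whole organism with Rattus norvegicus as the target, at a dose of 20 mg/kg by the oral route (a lower number here means less inhibition, a higher number more inhibition at the dose given (going by the name of the read-out)), compound 2 gives 45%, the higher of the two numbers so far. Its nearest neighbour is compound 1, which in this assay gives 15%, a gap that lies beyond the usual scatter. The two compounds differ in more than one place, so no single change can be read from them.

Compound 3, `O=C(/C=C1\CCc2ccc(F)cc21)NC1CCC1`, has not yet been measured. It differs from compound 2 in one place: cyclobutyl in place of ethyl on an amide-type nitrogen. Among the compounds with values here, no pair of measured compounds isolates this change, so its effect is unknown here. Because compound 2 gives 45% and the change adds only carbon and no donor or acceptor, the number for compound 3 is expected to sit close to that of compound 2. The expected step from compound 2 to compound 3 is a number 5 percentage points higher from compound 2 to compound 3 (within the scatter), that is, no change beyond the scatter. Compound 3 is estimated at 50%, with a range from 30% to 70%.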

Compound 3, a percentage reported as inhibition, in the whole organism at one dose (the size of the read-out at that dose, not a potency): 4%
Beside the measured number, compound 3's estimate is 46 percentage points above it; measured number below the stated range.
By their numbers in this assay, from the lowest: compound 3; then compound 1; then compound 2.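

Going by these compounds alone, compound 2 and compound 3 are the first pair in this assay that differ in one place, and cyclobutyl in place of ethyl on the amide-type nitrogen comes with a number 41 percentage points lower from compound 2 to compound 3 (beyond the scatter) in this comparison. The entering group adds carbon and a four-membered ring but no hydrogen-bond donor or acceptor, so this pair shows that the read-out at this position can move by a large step with a change in the carbon group alone. Nothing at hand bears on what lies behind this step.

The pair cannot separate the ring from the larger carbon group, and an open chain such as butyl on the same nitrogen would bear on that question. Also open, as far as these compounds go, are how a group carrying an amine or a hydroxyl would fare at this position, and whether the step would hold on the core of compound 1, which differs from compound 2 in more than one place.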